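Nitro for chloro on the amide aryl ring

The source may report more compounds than this note shows. Statements on the series, on what has been measured and on what is new or still open speak of the compounds shown alone.

The series shares one core, carried here by compound 1 `CC(=O)N(C)c1ccc2[nH]c(-c3n[nH]c4ccccc34)cc2n1` and compound 2 `CN(C(=O)c1ccc(Cl)cc1)c1ccc2[nH]c(-c3n[nH]c4ccccc34)cc2n1`. In a functional assay on SMMC-7721 cells (Homo sapiens) for antiproliferative activity, read by MTT assay, with a stated time of 72 h (a higher number here means a weaker inhibitor, a lower number a stronger inhibitor), compound 1 gives 23400 nM and compound 2 gives 2420 nM. Going by the values given here, the one measured step, a 9.7-fold lower number from compound 1 to compound 2 (0.99 log units; beyond the scatter), puts 4-chlorophenyl in place of methyl on the carbonyl carbon. Compound 2 thus stands at the lowest of the two numbers, with compound 1 the nearest at a higher one.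

Compound 3 `CN(C(=O)c1ccc([N+](=O)[O-])cc1)c1ccc2[nH]c(-c3n[nH]c4ccccc34)cc2n1` is not yet measured. It differs from compound 2 in one place: nitro in place of chloro on an aromatic carbon, so that 4-chlorophenyl becomes 4-nitrophenyl. Among the compounds with values here, no measured step exchanges one substituent on that aromatic ring for another; the step from compound 1 to compound 2 concerns the whole group on the carbonyl carbon and bears on the new change only in showing that the aryl amide is the one with the lower number. The exchange within the ring is therefore expected to shift this assay by no more than the scatter, in either direction. The estimate for compound 3 is 2400 nM, between 900 nM and 6500 nM. That is expected to amount to a 1.0-fold lower number from compound 2 to compound 3 (0.00 log units; within the scatter).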

Compound 3, half-maximal inhibitory concentration: 18400 nM
Compound 3: the middle estimate sits 7.7-fold (0.88 log units) below what was measured; measured number above the stated range.
By their numbers in this assay, from the lowest: compound 2; then compounds 3 and 1 (each within the scatter of the next).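

In this assay the substituent on the amide aryl ring proves to matter: with a 7.6-fold higher number from compound 2 to compound 3 (0.88 log units; beyond the scatter), nitro in place of chloro removes most of what the 4-chlorophenyl amide had over the methyl amide. An aryl amide alone is therefore not enough for the lower number, since a 1.3-fold lower number from compound 1 to compound 3 (0.10 log units; within the scatter) leaves the 4-nitrophenyl amide level with the methyl amide, and among these three compounds only compound 2 stands apart. No measured evidence at hand accounts for the difference between chloro and nitro at this position.

A single pair cannot tell whether chloro is the favourable exception or nitro the unfavourable one; an unsubstituted phenyl, or a fluoro, methoxy or amino group on the same ring carbon, would be needed to separate the two readings. Also open, from the compounds shown here alone, is whether the gap between chloro and nitro holds in other cell lines, as every number here comes from this assay alone.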